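The compounds below may be only part of what the source reports. "The series", "measured", "known", "first", "only" and "open" are said of these compounds alone.

Compound 1 `CN(C)C(=O)c1cc2cnc(Nc3ccc(NC(=O)C4(C(=O)Nc5cccc(F)c5)CC4)cc3)nc2n1C1CCCC1`: 29.7%
Compound 2 `CN(C)C(=O)c1cc2cnc(Nc3ccc(NC(=O)C4(C(=O)Nc5cccc(O)c5)CC4)cc3)nc2n1C1CCCC1`: -19.8%

In a functional assay on SiHa cells (Homo sapiens) for inhibition, read by CCK-8 assay, with a stated time of 72 h, tested at 1 uM (on this read-out lower numbers stand for less inhibition of growth and higher numbers for more inhibition of growth at the one concentration tested), compound 2 gives -19.8%, the lower of the two numbers and clearly under compound 1 at 29.7%. Compound 3 `CN(C)C(=O)c1cc2cnc(Nc3ccc(NC(=O)C4(C(=O)Nc5cccc(Cl)c5)CC4)cc3)nc2n1C1CCCC1` carries chloro in place of hydroxy on an aromatic carbon, meta to a large group: chloro in place of hydroxy on an aromatic carbon. Within the data shown here, the only measured step that bears on this is a number 49.5 percentage points lower from compound 1 to compound 2 (beyond the scatter), which put hydroxy in place of fluoro. Among the measured compounds shown here, the new change also removes hydroxy, so a large rise of similar size is expected, though no chloro compound has been measured yet. The expected step is a number 49.8 percentage points higher from compound 2 to compound 3 (beyond the scatter). For compound 3 the estimated value is 30%, with an expected range from 5% to 55%.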

Compound 3, percent growth inhibition at one concentration: 16.2%
Estimate against measurement, compound 3: 13.8 percentage points above; the range from low to high includes it.
By their numbers in this assay, from the lowest: compound 2; then compound 3; then compound 1.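

In this assay, the low number of the hydroxy compound is also seen against a second halogen: a number 36 percentage points higher from compound 2 to compound 3 (beyond the scatter). The two halogens do not give the same result at this position either, with a number 13.5 percentage points lower from compound 1 to compound 3 (beyond the scatter). Nothing available here explains these differences. On these data alone, whether an amine or a methoxy group in this same place would read like hydroxy or like the halogens stays open. So does how plain hydrogen, with no group at this position on the phenyl ring, would compare with chloro and fluoro.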